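The source may report more compounds than this note shows. Statements on the series, on what has been measured and on what is new or still open speak of the compounds shown alone.

Measured so far:
compound 1 `COc1ccc(Cn2c(CCc3ccccc3)nnc2[C@H](NC(=O)c2ccccn2)c2c[nH]c3ccccc23)c(OC)c1`: 1.1 nM
compound 2 `COc1ccc(-n2c(CCc3ccccc3)nnc2[C@H](NC(=O)c2ccccn2)c2c[nH]c3ccccc23)c(OC)c1`: 33 nM
compound 3 `COc1ccc(Cn2c(CCc3c[nH]c4ccccc34)nnc2[C@H](NC(=O)c2ccccn2)c2c[nH]c3ccccc23)cc1`: 1.9 nM

In an in vitro assay on LLC-PK1 cells for displacement of a labelled ligand from growth hormone secretagogue receptor type 1 (Homo sapiens) (on this read-out higher numbers stand for weaker inhibition and lower numbers for stronger inhibition), compound 3 gives 1.9 nM, the second highest of the three numbers. Its nearest neighbour is compound 1 with 1.1 nM, and these two lie within the scatter of each other. Compound 2, with 33 nM, lies beyond the scatter from compound 3. Among the measured compounds shown here, the only single-point step among the measured compounds, a 30-fold higher number from compound 1 to compound 2 (1.48 log units; beyond the scatter), concerns the group on the aromatic nitrogen and is large.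

Compound 4 `COc1ccc(Cn2c(CCc3ccccc3)nnc2[C@H](NC(=O)c2ccccn2)c2c[nH]c3ccccc23)cc1` is not yet measured. It differs from compound 3 by phenyl in place of 1H-indol-3-yl on a saturated chain carbon, two bonds along the chain from an aromatic carbon. For the measured compounds named here, no measured step touches this chain; the step from compound 1 to compound 2 sits elsewhere in the molecule and gives no guide here. Compound 1 carries the phenethyl chain and compound 3 the 2-(1H-indol-3-yl)ethyl chain, and their values in this assay sit within the scatter of each other, although the two also differ in the group on the aromatic nitrogen. On that basis compound 4 is expected to give about 1.5 nM in this assay, with a range of 0.6 nM to 4 nM. The step of a 1.3-fold lower number from compound 3 to compound 4 (0.10 log units; within the scatter) is thus expected to be none beyond the scatter.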

Compound 4, half-maximal inhibitory concentration: 0.7 nM
Compound 4: the middle estimate sits 2.1-fold (0.33 log units) above what was measured; low and high end bracket the measured number.
By their numbers in this assay, from the lowest: compounds 4, 1 and 3 (each within the scatter of the next, the first and the last beyond it); then compound 2.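

In this assay, phenyl in place of 1H-indol-3-yl gives a 2.7-fold lower number from compound 3 to compound 4 (0.43 log units; beyond the scatter) and so moves the number down, which shows that the 1H-indol-3-yl group and its hydrogen-bond donor are not needed at this chain position for a low number. On the aromatic nitrogen, 4-methoxybenzyl in place of 2,4-dimethoxyphenyl gives a 47-fold lower number from compound 2 to compound 4 (1.67 log units; beyond the scatter) as a second large step of the same kind, while hydrogen in place of methoxy gives a 1.6-fold lower number from compound 1 to compound 4 (0.20 log units; within the scatter) and leaves the two benzyl groups unseparated. Nothing measured here gives a reason for these steps.

Still open, from the compounds shown here alone, is whether an amine or a carboxylic acid in place of phenyl is accepted on this chain. A longer chain than phenethyl also remains to be read.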